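Hydroxy to Methoxy, Repeated in a Second Series

The compounds below may be only part of what the source reports. "The series", "measured", "known", "first", "only" and "open" are said of these compounds alone.

Compound 1 `O=C(Nc1cccc(-n2cc(-c3ccncc3)c(-c3cc(O)cc(Cl)c3)n2)c1)Nc1ccc(Cl)c(Cl)c1`: -61.8%
Compound 2 `COc1cc(Cl)cc(-c2nn(-c3cccc(NC(=O)Nc4ccc(Cl)c(Cl)c4)c3)cc2-c2ccncc2)c1`: 4.38%
Compound 3 `O=C(Nc1cccc(-n2cc(-c3ccncc3)c(-c3cc(O)cc(Cl)c3)n2)c1)c1cc(C(F)(F)F)cc(C(F)(F)F)c1`: 69.3%

All three compounds were tested in a functional assay on UACC-62 cells (Homo sapiens) for inhibition, read by sulforhodamine B assay, with a stated time of 48 h, tested at 10 uM; a higher number here means a weaker effect of the compound at the concentration tested, a lower number a stronger effect. Compound 2 differs from compound 1 by methyl in place of hydrogen on an oxygen on an aromatic ring, and that change gave a number 66.2 percentage points higher from compound 1 to compound 2 (beyond the scatter). Compound 3 carries a different amide part; the difference between its core and that of compound 1 is not broken down here, and the two values alone show compound 3 far weaker. Compound 4 `COc1cc(Cl)cc(-c2nn(-c3cccc(NC(=O)c4cc(C(F)(F)F)cc(C(F)(F)F)c4)c3)cc2-c2ccncc2)c1` has not yet been measured in this assay; it differs from compound 3 by methyl in place of hydrogen on an oxygen on an aromatic ring, the same change as that from compound 1 to compound 2. The step that the estimate means, a number 15.7 percentage points higher from compound 3 to compound 4 (beyond the scatter), is expected to be smaller than the earlier one because compound 3 already stands at 69.3%, leaving little room upward. Compound 4 is expected to give about 85%, between 62% and 105%.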

Compound 4, a percentage reported as activity, at one concentration (the size of the read-out at that concentration, not a potency): 81.4%
Compound 4: middle estimate off by 3.6 percentage points, on the high side; the range from low to high includes it.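

In this assay, hydroxy to methoxy moved the number in the same direction on the second core, giving a number 12.1 percentage points higher from compound 3 to compound 4 (beyond the scatter). The direction of the change carried over from one core to the other, but its size did not: the same change on two cores in this assay, a number 66.2 percentage points higher (beyond the scatter) from compound 1 to compound 2 and a number 12.1 percentage points higher (beyond the scatter) from compound 3 to compound 4, 54.1 percentage points apart, beyond the scatter of two such steps Two pairs do not show whether the core itself or the starting value of compound 3, 69.3%, sets the size of the step, and they do not predict the step on any further core.

The compounds shown leave open how a longer chain on that oxygen, such as ethoxy, would read. They also leave open how an amine in place of the hydroxy would read on either core.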